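Replacing the Aryl Group on the Shared Core of Compound 1

This account rests on a few compounds, and the source may have more. Where it says the series, first, only, none or still open, it means among the compounds named here.

Compound 1, `FC(F)(F)c1ccc(CSc2nc(Nc3ccccc3C(F)(F)F)c3ccccc3n2)cc1`: in a functional assay on MGC-803 cells (Homo sapiens) for cytotoxicity, read by MTT assay, with a stated time of 72 h (on this read-out higher numbers stand for weaker inhibition and lower numbers for stronger inhibition), compound 1 reaches only the limit > 50000 nM.
Compound 2, `FC(F)(F)c1ccc(CSc2nc(Nc3cccc(Br)c3)c3ccccc3n2)cc1`: in this assay compound 2 gives 23700 nM.

Compound 1 stands at a limit of this assay, so its true number is not known, only that it lies beyond that boundary. Among the compounds with values here, the one measured step from it, to compound 2, is an at least 2.1-fold lower number from compound 1 to compound 2 (0.32 log units; beyond the scatter), and because compound 1 sits at the limit of > 50000 nM in this assay, at which 1 of the 2 values shown sits, that step is itself only a lower bound.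

Compound 3, `COc1ccc(Nc2nc(SCc3ccc(C(F)(F)F)cc3)nc3ccccc23)cc1OC`, differs from compound 1 in one place: 3,4-dimethoxyphenyl in place of 2-(trifluoromethyl)phenyl on a nitrogen on an aromatic ring. Within the data shown here, no measured pair shows this particular exchange. Among the measured compounds shown here, the only step that bears on it is the one from compound 1 to compound 2, where another aryl group took the place of the same 2-(trifluoromethyl)phenyl and the number fell at least modestly. On that basis a step of similar size and direction, an at least 2.0-fold lower number from compound 1 to compound 3 (0.30 log units; that floor lies within the scatter), is expected for compound 3. Compound 3 is therefore estimated at 25000 nM in this assay, with a range from 8000 nM to 80000 nM, and a real chance that only a limit is returned.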

Compound 3, half-maximal inhibitory concentration: 16300 nM
Beside the measured number, compound 3's estimate is 1.5-fold (0.19 log units) above it; the measured number falls inside the stated range.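

In this assay, a second aryl group on a nitrogen on an aromatic ring now also gives a lower number than 2-(trifluoromethyl)phenyl, with an at least 3.0-fold lower number from compound 1 to compound 3 (0.48 log units; beyond the scatter), so this gain at the position is not confined to the 3-bromophenyl of compound 2. On these data alone, the true size of that gain stays unknown because compound 1 is known only through a limit and not through a number: the limit of > 50000 nM in this assay, at which 1 of the 3 values shown sits. The two replacement groups themselves cannot be separated, since a 1.5-fold lower number from compound 2 to compound 3 (0.16 log units; within the scatter), which means that 3,4-dimethoxyphenyl, with its two oxygen atoms and two hydrogen-bond acceptors, and 3-bromophenyl, with its single halogen, read alike here despite their different make-up.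

The compounds shown leave open whether the gain comes from losing the 2-(trifluoromethyl)phenyl or from what enters in its place, a question that a plain phenyl group on the same nitrogen would speak to. They also leave open which of the two methoxy groups of compound 3 matters, if either does, and how a 3-methoxyphenyl, a 4-methoxyphenyl or an aryl group bearing a carboxylic acid or an amine would read on the shared core.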